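Nitro for methoxy on the ethoxycarbonyl analogue

A few compounds are considered here, and "the series" means these few. Any claim that something is new, unique, unknown or untested is made for them only; others in the source may bear on it.

The series shares one core and varies two positions. In a functional assay on A549 cells (Homo sapiens) for cytotoxicity, read by sulforhodamine B assay, with a stated time of 72 h (a lower number here means a stronger inhibitor, a higher number a weaker inhibitor), compound 1 `COc1ccc(-n2nc(C(C)=O)s/c2=N\c2nc(-c3c(C)n(C)n(-c4ccccc4)c3=O)cs2)cc1` gives 26500 nM. Compound 3 `CCOC(=O)c1nn(-c2ccc(OC)cc2)/c(=N/c2nc(-c3c(C)n(C)n(-c4ccccc4)c3=O)cs2)s1` carries ethoxy in place of methyl on a carbonyl carbon and in this assay gives 13100 nM; the step of a 2.0-fold lower number from compound 1 to compound 3 (0.31 log units; beyond the scatter) is modest. Compound 2 `CC(=O)c1nn(-c2ccc([N+](=O)[O-])cc2)/c(=N/c2nc(-c3c(C)n(C)n(-c4ccccc4)c3=O)cs2)s1` carries nitro in place of methoxy on an aromatic carbon. In this assay compound 2 reaches only a limit, > 100000 nM. The step of an at least 3.7-fold higher number from compound 1 to compound 2 (0.57 log units; beyond the scatter) is therefore open at its upper end; compound 2 sits at the limit of > 100000 nM in this assay, at which 1 of the 3 values shown sits.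

Compound 4 `CCOC(=O)c1nn(-c2ccc([N+](=O)[O-])cc2)/c(=N/c2nc(-c3c(C)n(C)n(-c4ccccc4)c3=O)cs2)s1` is not yet measured in this assay. It differs from compound 3 by nitro in place of methoxy on an aromatic carbon, the same change as from compound 1 to compound 2, made on a core that differs from that of compound 1 by ethoxy in place of methyl on a carbonyl carbon. The place of the change is described in the same words for both pairs.

Going by the values given here, the one measured instance of this change, an at least 3.7-fold higher number from compound 1 to compound 2 (0.57 log units; beyond the scatter), points to a weaker inhibitor, and it gives only a lower bound for the size. Compound 3 starts at a lower number than compound 1, so compound 4 may or may not stay within the range of the assay. For compound 4 the expected step is a 5.3-fold higher number from compound 3 to compound 4 (0.73 log units; beyond the scatter), which rests on the measured step of an at least 3.7-fold higher number from compound 1 to compound 2 (0.57 log units; beyond the scatter). Compound 4 is expected to give 70000 nM in this assay, with a likely span from 30000 nM to 200000 nM, and a substantial chance that only a limit is reported.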

Compound 4, half-maximal inhibitory concentration: 8680 nM
For compound 4 the middle estimate is 8.1-fold (0.91 log units) above the measured one; measured number below the stated range.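

In this assay, nitro in place of methoxy on the core of compound 3 gives a 1.5-fold lower number from compound 3 to compound 4 (0.18 log units; within the scatter), so the loss seen on the core of compound 1 does not carry over to this core: the same change on two cores in this assay, an at least 3.7-fold higher number (0.57 log units; beyond the scatter) from compound 1 to compound 2 and a 1.5-fold lower number (0.18 log units; within the scatter) from compound 3 to compound 4, at least 5.6-fold (0.75 log units) apart, beyond the scatter of two such steps

Read along the other position, ethoxy in place of methyl on a carbonyl carbon gives an at least 11-fold lower number from compound 2 to compound 4 (1.06 log units; beyond the scatter) between the two nitro compounds, and this step does not match the one between the two methoxy compounds: the same change on two cores in this assay, a 2.0-fold lower number (0.31 log units; beyond the scatter) from compound 1 to compound 3 and an at least 11-fold lower number (1.06 log units; beyond the scatter) from compound 2 to compound 4, at least 5.6-fold (0.75 log units) apart, beyond the scatter of two such steps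

Compound 2 stands at > 100000 nM, which is a limit and not a number, so the true gap between the two pairs could be wider than printed; the four compounds show that the effect of either change depends on the group at the other position, but they do not show why, and they cover only this one set of two groups at each position.

The compounds shown leave open whether a group such as an amine or a carboxylic acid in place of the nitro would follow the methyl or the ethoxy pattern. From the compounds shown here alone, it is also open whether a longer chain on the ester oxygen would keep the nitro compound within the range of the assay, as ethoxy does in compound 4.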